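Taking Away One Methoxy Group: What Cytotoxicity to Expect

A few compounds are considered here, and "the series" means these few. Any claim that something is new, unique, unknown or untested is made for them only; others in the source may bear on it.

Measured so far:
Compound 1, `COc1ccc(-c2[nH]c3ccccc3c2/C=C(\C#N)S(=O)(=O)c2ccccc2)cc1`: 300 nM
Compound 2, `COc1ccc(-c2[nH]c3ccc(OC)cc3c2/C=C(\C#N)S(=O)(=O)c2ccccc2)cc1`: 300 nM

In a functional assay on CCRF-SB cells (Homo sapiens) for cytotoxicity, read by MTT assay, with a stated time of 96 h (on this read-out higher numbers stand for an effect only at larger amounts of compound and lower numbers for an effect already at smaller amounts), compound 1 gives 300 nM and compound 2 gives 300 nM. For the measured compounds named here, the single measured step, no change at the digits printed from compound 1 to compound 2 (within the scatter), shows that adding a methoxy group to an aromatic carbon of the shared core left the read-out where it was. Compound 2 therefore stands level with compound 1; neither can be called the more active of the two.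

Compound 3, `COc1ccc2[nH]c(-c3ccccc3)c(/C=C(\C#N)S(=O)(=O)c3ccccc3)c2c1`, keeps everything of compound 2 except one change: hydrogen in place of methoxy on an aromatic carbon. Going by the values given here, the only measured step that bears on this, no change at the digits printed from compound 1 to compound 2 (within the scatter), swaps the same two groups, hydrogen and methoxy, although at another place on the molecule, and it produced no movement beyond the usual scatter. With no other evidence, the expected step is likewise flat: a 1.3-fold higher number from compound 2 to compound 3 (0.12 log units; within the scatter) is the expected outcome, in no particular direction.

Compound 3 is thus estimated to give 400 nM in this assay, within a range of 150 nM to 1500 nM.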

Compound 3, half-maximal effective concentration: 1900 nM
For compound 3 the middle estimate is 4.8-fold (0.68 log units) below the measured one; the whole stated range lies below it.
By their numbers in this assay, from the lowest: compounds 1 and 2 (each within the scatter of the next); then compound 3.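

In this assay the methoxy of the 4-methoxyphenyl group cannot be swapped for hydrogen without a cost: the change gives a 6.3-fold higher number from compound 2 to compound 3 (0.80 log units; beyond the scatter) and so moves the read-out beyond the scatter, although only modestly. The earlier result, no change at the digits printed from compound 1 to compound 2 (within the scatter) and within the scatter, involved the same two groups at another place on the molecule, so the two steps together show that what this exchange does depends on where it is made, and a flat result at one place did not carry over to the other. Nothing shown here gives a measured reason why one place responds and the other does not.

On these data alone, only methoxy and hydrogen appear at this place on the ring, so it stays open whether methoxy itself matters or whether another group would serve as well, such as a hydroxyl, an ethoxy, a fluorine or an amine. Also open, as far as these compounds go, is whether the same step would appear in cells other than those of this assay and whether it would hold on a core lacking the second methoxy.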